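Compound 1 to compound 4: changing the aromatic nitrogen substituent

The source may report more compounds than this note shows. Statements on the series, on what has been measured and on what is new or still open speak of the compounds shown alone.

Values measured in a functional assay on FaDu cells (Homo sapiens) for cytotoxicity, read by MTT assay, with a stated time of 72 h (on this read-out lower numbers stand for higher toxicity in this test and higher numbers for lower toxicity in this test), follow
- Compound 1 `COc1ncc(NC(=O)C(=O)c2cn(C(C)C)c3ccccc23)cn1` gives 171 nM
- Compound 2 `COc1ccc(NC(=O)C(=O)c2cn(C(C)C)c3ccccc23)cc1` gives 181 nM
- Compound 3 `COc1nc(NC(=O)C(=O)c2cn(C(C)C)c3ccccc23)ns1` gives > 10000 nM as a limit of the assay, not a number

Compound 1 stands at the low end of the numbers, level with compound 2 (a 1.1-fold higher number from compound 1 to compound 2 (0.02 log units; within the scatter)). The steps to the limit value are large (an at least 58-fold higher number from compound 1 to compound 3 (1.76 log units; beyond the scatter); an at least 55-fold higher number from compound 2 to compound 3 (1.74 log units; beyond the scatter)).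

Compound 4 `COCCn1cc(C(=O)C(=O)Nc2cnc(OC)nc2)c2ccccc21` differs from compound 1 by one change (2-methoxyethyl in place of isopropyl on an aromatic nitrogen), with 2-methoxyethyl in place of isopropyl on an aromatic nitrogen. All three measured steps fall on an amide-type nitrogen and none on the aromatic nitrogen, which leaves the size of this change without direct measurement. A modest rise in this assay is expected, close to the edge of the scatter, and the upper range is kept wide given the large step of an at least 58-fold higher number from compound 1 to compound 3 (1.76 log units; beyond the scatter) elsewhere on compound 1. The expected step is a 2.3-fold higher number from compound 1 to compound 4 (0.37 log units; beyond the scatter) as an estimate only. For compound 4 the estimated value is 400 nM (expected range 120 nM to 2500 nM).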

Compound 4, concentration lethal to 50% of the cells: 55 nM
Estimate against measurement, compound 4: 7.3-fold (0.86 log units) above; measured number outside the range, below it.
By their numbers in this assay, from the lowest: compound 4; then compounds 1 and 2 (each within the scatter of the next). At a limit, above all of these: compound 3.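

Within the data shown here, the aromatic nitrogen is a second site that moves the number in this assay, since the earlier steps all fell on the amide-type nitrogen: 2-methoxyethyl in place of isopropyl gives a 3.1-fold lower number from compound 1 to compound 4 (0.49 log units; beyond the scatter). The change therefore runs towards higher toxicity in this test, so a chain carrying an oxygen is accepted at this position on the core of compound 1. No available measurement bears on the reason for this step.

From the compounds shown here alone, whether the oxygen or the extra chain atom drives the step stays open, and a plain n-butyl chain, a 2-hydroxyethyl or a 2-aminoethyl on the aromatic nitrogen would separate the two. Also open, going by these compounds, is whether the step carries over to the 4-methoxyphenyl amide of compound 2.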